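The source may report more compounds than this note shows. Statements on the series, on what has been measured and on what is new or still open speak of the compounds shown alone.

Compound 1 `O=c1[nH]cc(S(=O)(=O)Nc2ccccc2-c2cn(-c3cccc(F)c3)nn2)c(=O)[nH]1` in a functional assay on OVCAR-3 cells (Homo sapiens) for antiproliferative activity, read by MTT assay, with a stated time of 24 h (on this read-out lower numbers stand for stronger inhibition and higher numbers for weaker inhibition), gives > 20000 nM, a limit of the assay. Compound 2 `O=c1[nH]cc(S(=O)(=O)Nc2cccc(-c3cn(-c4ccccc4)nn3)c2)c(=O)[nH]1` in this assay gives > 20000 nM, again a limit. Compound 3 `Cc1ccccc1-n1cc(-c2cccc(NS(=O)(=O)c3c[nH]c(=O)[nH]c3=O)c2)nn1` in this assay gives 6230 nM.

Among the measured compounds shown here, compound 3 therefore stands as the only compound with a number in this assay; the other two values sit at the limit of > 20000 nM in this assay, at which 2 of the 3 values shown sit. For the measured compounds named here, the single measured step is an at least 3.2-fold lower number from compound 2 to compound 3 (0.50 log units; beyond the scatter), a methyl added to the phenyl ring.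

Compound 4 `Cc1cccc(-n2cc(-c3cccc(NS(=O)(=O)c4c[nH]c(=O)[nH]c4=O)c3)nn2)c1` differs from compound 3 by 3-methylphenyl in place of 2-methylphenyl on an aromatic nitrogen. Going by the values given here, no measured step compares two positions of the methyl, so the direction of this move is open; the only guide is that the methylated compound 3 gives a number while compound 2 gives a limit. Compound 4 is expected to give about 8000 nM, between 2500 nM and 25000 nM, a step of a 1.3-fold higher number from compound 3 to compound 4 (0.11 log units; within the scatter) within the scatter.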

Compound 4, half-maximal inhibitory concentration: 4080 nM
Compound 4: the middle estimate sits 2.0-fold (0.29 log units) above what was measured, within the range that was stated.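

Moving the methyl from 2-methylphenyl to 3-methylphenyl on the aromatic nitrogen gives a 1.5-fold lower number from compound 3 to compound 4 (0.18 log units; within the scatter), so this assay does not separate the two placements. A second methylated compound now gives a number, with an at least 4.9-fold lower number from compound 2 to compound 4 (0.69 log units; beyond the scatter), so the step from the unsubstituted phenyl no longer rests on a single placement of the methyl.

As far as these compounds go, the full size of that step stays open because its starting value is a limit: the limit of > 20000 nM in this assay, at which 2 of the 4 values shown sit. Also open is how an amine or a carboxylic acid in place of the methyl would read out in this assay.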